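From chloro to methoxycarbonyl at the end of the chain

The source may hold more compounds than are shown below. What is called first, only, known or untested is meant among the compounds shown, and "the series" means these compounds.

In a functional assay for inhibition, with Homo sapiens as the target (on this read-out higher numbers stand for weaker inhibition and lower numbers for stronger inhibition), compound 1 (`COc1cc(OC)c(C(=O)/C=C/c2ccc(Cl)cc2)c(OC)c1`) gives 970 nM, compound 2 (`COc1cc(OC)c(C(=O)/C=C/c2c(Cl)cccc2Cl)c(OC)c1`) gives 1090 nM and compound 3 (`COc1cc(OC)c(C(=O)/C=C/c2cnccn2)c(OC)c1`) gives 693 nM. Compound 1 therefore stands level with both others, within the scatter. Compound 4 (`COC(=O)c1ccc(/C=C/C(=O)c2c(OC)cc(OC)cc2OC)cc1`) has not yet been measured. It carries methoxycarbonyl in place of chloro on an aromatic carbon, para to a large group: methoxycarbonyl in place of chloro on an aromatic carbon. Two measured steps alter the same end of compound 1: a 1.1-fold higher number from compound 1 to compound 2 (0.05 log units; within the scatter) and a 1.4-fold lower number from compound 1 to compound 3 (0.15 log units; within the scatter). Both are small, even though the second replaces the whole 4-chlorophenyl, so no step beyond the scatter is expected in this assay. The estimated step is a 1.1-fold lower number from compound 1 to compound 4 (0.03 log units; within the scatter). The expected value for compound 4 is 900 nM, with an estimated range from 450 nM to 1800 nM.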

Compound 4, half-maximal inhibitory concentration: 1930 nM
For compound 4 the middle estimate is 2.1-fold (0.33 log units) below the measured one; measured number above the stated range.
By their numbers in this assay, from the lowest: compounds 3, 1, 2 and 4 (each within the scatter of the next, the first and the last beyond it).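

At the position para to a large group, methoxycarbonyl in place of chloro gives a 2.0-fold higher number from compound 1 to compound 4 (0.30 log units; within the scatter) in this assay, so even this larger ester group, with its 2 hydrogen-bond acceptors, leaves the number level with compound 1. Within the data shown here, compound 3 at 693 nM and compound 4 at 1930 nM are now the only two of the four compounds that stand beyond the scatter of each other. No evidence here explains the size of this step. From the compounds shown here alone, whether a carboxylic acid or an amine at this position would move the number beyond the scatter of compound 1 remains open.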